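This account rests on a few compounds, and the source may have more. Where it says the series, first, only, none or still open, it means among the compounds named here.

Measured compounds:
Compound 1, `COc1ccc(-c2nnc(SCC(=O)Nc3ccc(/C(C)=N/O)cc3)n2-c2ccccc2)cc1`: 56%
Compound 2, `C=CCn1c(SCC(=O)Nc2ccc(/C(C)=N/O)cc2)nnc1-c1ccc(OC)cc1`: 59%
Compound 3, `C=CCn1c(SCC(=O)Nc2ccc(C(C)=O)cc2)nnc1-c1ccc(OC)cc1`: 51%

All three were tested in a functional assay on the whole organism (strain albino) for inhibition, with Rattus norvegicus as the target, read by paw edema, with stated times of 30 min and 2 h, at a dose of 0.28 mmol/kg by the oral route; on this read-out higher numbers stand for more inhibition at the one dose given (going by the name of the read-out) and lower numbers for less inhibition. Compound 2 and compound 1 differ by phenyl in place of allyl on an aromatic nitrogen, and this change gave a number 3 percentage points lower from compound 2 to compound 1 (within the scatter). Compound 2 and compound 3 differ in the core by a group of 3 heavy atoms (2 carbon, 1 oxygen; no ring) in place of a group of 4 heavy atoms (2 carbon, 1 nitrogen, 1 oxygen; no ring), on an aromatic carbon, with a number 8 percentage points lower from compound 2 to compound 3 (within the scatter). Compound 1 and compound 3 are separated by a gap that stays within the scatter, so no order among the three can be read from these numbers.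

Compound 4, `COc1ccc(-c2nnc(SCC(=O)Nc3ccc(C(C)=O)cc3)n2-c2ccccc2)cc1`, has not yet been measured in this assay. It differs from compound 3 by phenyl in place of allyl on an aromatic nitrogen. For the measured compounds named here, this is the same change as the one from compound 2 to compound 1, made at the same place and described in the same words, but on the core of compound 3 rather than on the core of compound 2.

Compound 4 is expected to give about 49% in this assay because the same change earlier gave a number 3 percentage points lower from compound 2 to compound 1 (within the scatter). For compound 4 this means an expected a number 2 percentage points lower from compound 3 to compound 4 (within the scatter). The estimated range for compound 4 runs from 39% to 59%.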

Compound 4, a percentage reported as inhibition, in the whole organism at one dose (the size of the read-out at that dose, not a potency): 42%
Compound 4: middle estimate off by 7 percentage points, on the high side; the measured number falls inside the stated range.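

In this assay, phenyl in place of allyl on the aromatic nitrogen gave a number 9 percentage points lower from compound 3 to compound 4 (within the scatter), and set beside the earlier step on the core of compound 2, this change shows no difference between the two cores: the same change on two cores in this assay, a number 3 percentage points lower (within the scatter) from compound 2 to compound 1 and a number 9 percentage points lower (within the scatter) from compound 3 to compound 4, 6 percentage points apart, within the scatter of two such steps. For the compounds shown here, the change on the aromatic carbon gave a number 14 percentage points lower from compound 1 to compound 4 (beyond the scatter), the only one of the four steps beyond the scatter, yet it cannot be told apart from its counterpart on the other core: the same change on two cores in this assay, a number 8 percentage points lower (within the scatter) from compound 2 to compound 3 and a number 14 percentage points lower (beyond the scatter) from compound 1 to compound 4, 6 percentage points apart, within the scatter of two such steps. These pairs show that both changes can be carried between these two cores within the precision of this single-dose read-out, but they do not show that the steps are exactly additive or that they would hold on any other core.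

The compounds shown leave open how a longer chain on the aromatic nitrogen would compare with allyl and phenyl. They also leave open what an amine or a carboxylic acid would give on the aromatic carbon, and what replacing the 4-methoxyphenyl group would do.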